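The compounds below may be only part of what the source reports. "The series", "measured", "known", "first", "only" and "open" are said of these compounds alone.

Measured compounds:
compound 1 `COc1ccccc1/C=c1/[nH]c(=O)/c(=C\c2ccccc2OC)n(C)c1=O`, 16200 nM in a functional assay on HL-60 cells (Homo sapiens) for cytotoxicity, read by CCK-8 assay, with a stated time of 72 h; a higher number here means a weaker inhibitor, a lower number a stronger inhibitor
compound 2 `C=CCn1c(=O)/c(=C\c2ccccc2Cl)[nH]c(=O)/c1=C\c1ccccc1OC`, 4200 nM
compound 3 `C=CCn1c(=O)/c(=C\c2cccc(Br)c2)[nH]c(=O)/c1=C\c1ccccc1OC`, 5200 nM

Compound 1 gives the highest number of the three in this assay; compound 3 and compound 2 both sit beyond the scatter below it. Compound 4 `COc1ccccc1/C=c1\c(=O)[nH]/c(=C/c2cccc(Cl)c2Cl)c(=O)n1C` differs from compound 1 by 2,3-dichlorophenyl in place of 2-methoxyphenyl on a double-bonded chain carbon bound to an aromatic carbon. Going by the values given here, no measured step matches this change directly. The nearest step, a 1.2-fold higher number from compound 2 to compound 3 (0.09 log units; within the scatter), exchanges one halophenyl for another and shows no shift. Compound 2 and compound 3, each carrying one halophenyl, sit well below compound 1, but they also differ from it at the ring nitrogen, so that gap cannot be assigned to the aryl change alone. A moderate lowering is therefore expected: a 2.5-fold lower number from compound 1 to compound 4 (0.40 log units; beyond the scatter). The estimated value for compound 4 is 6500 nM, range 2500 nM to 17000 nM.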

Compound 4, half-maximal inhibitory concentration: 200 nM
Compound 4: the middle estimate sits 33-fold (1.51 log units) above what was measured; measured number below the stated range.
By their numbers in this assay, from the lowest: compound 4; then compounds 2 and 3 (each within the scatter of the next); then compound 1.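

In this assay, the aryl group on a double-bonded chain carbon bound to an aromatic carbon proves a strong lever: 2,3-dichlorophenyl in place of 2-methoxyphenyl gives the large step (an 81-fold lower number from compound 1 to compound 4 (1.91 log units; beyond the scatter)). The earlier exchange of one halophenyl for another (a 1.2-fold higher number from compound 2 to compound 3 (0.09 log units; within the scatter)) showed no such sensitivity at this place. No supporting data on hand explain the size of this step.

Whether a single chlorine on this phenyl, on the core of compound 1, would account for most of the step remains open. Also open, as far as these compounds go, is how an amine or a carboxylic acid on this phenyl would fare.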